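Notes on amide variation and paw edema inhibition

The compounds below may be only part of what the source reports. "The series", "measured", "known", "first", "only" and "open" are said of these compounds alone.

Measured so far:
compound 1 `CCCCCNC(=O)CC1CCc2cc(OC)c(OC)cc21`: 35.2%
compound 2 `COc1cc2c(cc1OC)C(CC(=O)NC1CCCC1)CC2`: 40.7%

Both were run in a functional assay on the whole organism (strain Wistar) for inhibition, with Rattus norvegicus as the target, read by paw edema, with stated times of 60 min and 6 h, at a dose of 100 mg/kg by the oral route; a higher number here means more inhibition at the dose given (going by the name of the read-out), a lower number less inhibition. Compound 2 gives the larger of the two numbers, with compound 1 nearest. The step of a number 5.5 percentage points higher from compound 1 to compound 2 (within the scatter) lies within the scatter, so the two are not separated.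

Compound 3 `COc1cc2c(cc1OC)C(CC(=O)N1CCCC1)CC2` differs from compound 2 by pyrrolidin-1-yl in place of cyclopentylamino on a carbonyl carbon. Within the data shown here, no measured step touches this change; the only known step, cyclopentyl in place of pentyl on an amide-type nitrogen, stayed within the scatter. An expected step of a number 2.7 percentage points lower from compound 2 to compound 3 (within the scatter) therefore means no movement beyond the scatter. Compound 3 is estimated at 38%, between 22% and 54%.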

Compound 3, a percentage reported as inhibition, in the whole organism at one dose (the size of the read-out at that dose, not a potency): 22.2%
Estimate against measurement, compound 3: 15.8 percentage points above, within the range that was stated.
By their numbers in this assay, from the lowest: compound 3; then compounds 1 and 2 (each within the scatter of the next).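

Pyrrolidin-1-yl on the carbonyl carbon gives the only changes in this set that clear the scatter in this assay, with a number 18.5 percentage points lower from compound 2 to compound 3 (beyond the scatter) and a number 13 percentage points lower from compound 1 to compound 3 (beyond the scatter). So this position does respond to the group on the amide nitrogen, which the step between pentyl and cyclopentyl did not show. Pyrrolidin-1-yl has 0 hydrogen-bond donors against 1 for cyclopentylamino, but no evidence is available on what lies behind the lower number.

Open, going by these compounds, is whether a piperidine or morpholine amide would stay at the level of compound 3. Also open, on these data alone, is how a simple dimethylamino group would read at the same carbonyl carbon.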